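From Phenyl to Thiophen-2-yl on the Shared Core

The source may report more compounds than this note shows. Statements on the series, on what has been measured and on what is new or still open speak of the compounds shown alone.

Measured so far in an assay on isolated protein for inhibition of DNA topoisomerase 1 (Homo sapiens), with a stated time of 30 min, tested at 100 uM; on this read-out lower numbers stand for a weaker effect and higher numbers for a stronger effect at the one concentration tested:
Compound 1 `Oc1ccc(-c2cc(-c3cccnc3)nc(-c3ccccc3Cl)c2)cc1` gives 0.9%
Compound 2 `Oc1cccc(-c2cc(-c3ccc(Cl)cc3)nc(-c3ccco3)c2)c1` gives 27.1%
Compound 3 `Oc1ccc(-c2cc(-c3ccccc3)nc(-c3ccccc3Cl)c2)cc1` gives 13.6%

Compound 3 stands second highest of the three numbers in this assay: compound 1 lies below it, beyond the scatter, and compound 2 lies above it, also beyond the scatter.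

The step now followed goes from compound 3 to compound 4 `Oc1ccc(-c2cc(-c3cccs3)nc(-c3ccccc3Cl)c2)cc1`, which differs by thiophen-2-yl in place of phenyl on an aromatic carbon. Among the measured compounds shown here, the one measured step, a number 12.7 percentage points higher from compound 1 to compound 3 (beyond the scatter), swaps a six-membered ring with one nitrogen for a plain six-membered ring at the same place; it says nothing direct about a five-membered sulfur ring entering there. Compound 2 carries a five-membered oxygen ring at a different place and has other groups as well, so its value cannot be tied to this change. For the measured compounds named here, with no bearing step, the expected change in this assay is none beyond the scatter, which the estimated a number 1.4 percentage points higher from compound 3 to compound 4 (within the scatter) reflects. Compound 4 is therefore expected to give 15%, within a range from 3% to 32%.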

Compound 4, a percentage reported as inhibition, at one concentration (the size of the read-out at that concentration, not a potency): 2.2%
The estimate for compound 4 lay 12.8 percentage points above the measured number; measured number below the stated range.
By their numbers in this assay, from the lowest: compounds 1 and 4 (each within the scatter of the next); then compound 3; then compound 2.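

In this assay, the place next to the ring nitrogen of the shared core now has a third ring to compare, and thiophen-2-yl in place of phenyl gives a number 11.4 percentage points lower from compound 3 to compound 4 (beyond the scatter). This shows that a five-membered sulfur ring does not keep the higher number seen with phenyl, while against pyridin-3-yl the same ring gives a number 1.3 percentage points higher from compound 1 to compound 4 (within the scatter), so among these three compounds only the phenyl compound stands apart. Nothing measured here bears on why phenyl differs from the other two rings.

Open, going by these compounds, is whether a non-ring group at this place, such as an amine, a carboxylic acid or a longer chain, would give a number above or below that of phenyl. Also open, on these data alone, is whether a substituted phenyl ring would raise the number further.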